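Methoxy for methyl on the anilino ring of the pyrimidine series

The compounds below may be only part of what the source reports. "The series", "measured", "known", "first", "only" and "open" are said of these compounds alone.

Measured compounds:
compound 1 `Cc1cccc(Nc2nccc(-c3ccc(Br)cc3)n2)c1`, > 1000 nM
compound 2 `COc1cccc(Nc2nccc(-c3ccc(Br)cc3)n2)c1`, 977 nM
compound 3 `Cc1cccc(Nc2nccc(-c3ccc(Cl)cc3Cl)n2)c1`, 851 nM

In an assay on isolated protein for inhibition of phosphatidylinositol 4,5-bisphosphate 3-kinase catalytic subunit beta isoform (Homo sapiens) (a higher number here means a weaker inhibitor, a lower number a stronger inhibitor), compound 1 sits at the limit (the limit of > 1000 nM in this assay, at which 1 of the 3 values shown sits), a limit and not a number. Compound 2 differs by methoxy in place of methyl on an aromatic carbon; the step is an at least 1.0-fold lower number from compound 1 to compound 2 (0.01 log units; that floor lies within the scatter), which says little given the limit. In this assay compound 3 gives 851 nM, within the scatter of compound 2. How the core of compound 3 differs from that of compound 1 is not broken down here. Compound 4 `COc1cccc(Nc2nccc(-c3ccc(Cl)cc3Cl)n2)c1` is not yet measured; it carries methoxy in place of methyl on an aromatic carbon, the same change as between compound 1 and compound 2. A step of about a 1.1-fold lower number from compound 3 to compound 4 (0.03 log units; within the scatter) is expected for compound 4, resting on the flat step seen from compound 1 to compound 2. Compound 4 is estimated at 800 nM, between 400 nM and 1600 nM.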

Compound 4, half-maximal inhibitory concentration: 893 nM
Beside the measured number, compound 4's estimate is 1.1-fold (0.05 log units) below it; low and high end bracket the measured number.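

In this assay, methoxy in place of methyl gives a 1.0-fold higher number from compound 3 to compound 4 (0.02 log units; within the scatter), so on this core the change leaves the number within the scatter. Set beside the earlier step, the two cores read as follows: the same change on two cores in this assay, an at least 1.0-fold lower number (0.01 log units; that floor lies within the scatter) from compound 1 to compound 2 and a 1.0-fold higher number (0.02 log units; within the scatter) from compound 3 to compound 4; the limit leaves it open whether they differ. Compound 1 stands at a limit, > 1000 nM, and not at a number, so the data do not show that the change carries over equally from one core to the other, only that nothing here speaks against it.

The compounds shown leave open whether another group on the same aromatic carbon, such as an amine or a carboxylic acid, would move the number beyond the scatter. They also leave open how this change behaves on any other core.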